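Swapping chloro for methoxy on an aromatic carbon

The source may hold more compounds than are shown below. What is called first, only, known or untested is meant among the compounds shown, and "the series" means these compounds.

Measured in a physicochemical assay for lipophilicity, read by HPLC, measured as octanol-water partition (on this read-out lower numbers stand for lower lipophilicity and higher numbers for higher lipophilicity), so far:
Compound 1 `COCCOCCC(Sc1ncnc2c1cnn2-c1ccccc1Cl)C(=O)Nc1nc(C)cs1` gives 4.7
Compound 2 `COCCC(Oc1ncnc2c1cnn2-c1ccccc1Cl)C(=O)Nc1ccc(C)cn1` gives 4.1
Compound 3 `COCC[C@H](Oc1ncnc2c1cnn2-c1ccccc1Cl)C(=O)Nc1ccc(C)cn1` gives 3.9

Compound 2 stands at 4.1 and compound 1 at 4.7, a gap that lies beyond the scatter, and compound 2 is level with compound 3 within the scatter. Compound 4 `COCCC(Oc1ncnc2c1cnn2-c1ccccc1OC)C(=O)Nc1ccc(C)cn1` is still unmeasured. Relative to compound 2 it carries methoxy in place of chloro on an aromatic carbon on an aromatic carbon, so 2-chlorophenyl becomes 2-methoxyphenyl. Among the compounds with values here, the one measured step, a number 0.20 log units lower from compound 2 to compound 3 (within the scatter) reflects only the fact that one of compounds 2 and 3 is drawn with a defined configuration and the other without, at the place where they differ and leaves the chloro untouched. Within the data shown here, no measured step therefore gives a size for this swap, and the expectation rests on the structural change alone. A lower number is expected, with the estimated step of a number 0.50 log units lower from compound 2 to compound 4 (beyond the scatter) in this assay modestly beyond the scatter. Compound 4 is estimated at 3.6 with a range from 3.2 to 4 expected.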

Compound 4, distribution coefficient: 3.5
Compound 4: middle estimate off by 0.10 log units, on the high side; measured number inside the range.
By their numbers in this assay, from the lowest: compound 4; then compounds 3 and 2 (each within the scatter of the next); then compound 1.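

In this assay, within the data shown here, the group on this aromatic carbon proves able to shift the number: methoxy in place of chloro gives a number 0.60 log units lower from compound 2 to compound 4 (beyond the scatter) and so puts a first size on a change at this place. The earlier step between measured compounds left the chloro untouched. Nothing among the facts at hand accounts for the size of this step.

The compounds shown leave open how an amine or a fluoro group on this carbon would read. Also open, on these data alone, is whether the same swap would give a similar step on compound 1.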